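This account rests on a few compounds, and the source may have more. Where it says the series, first, only, none or still open, it means among the compounds named here.

- compound 1 `COC(=O)[C@H](CC(C)C)NC(=O)CCC(=O)Oc1ccc(C[C@H]2C(=O)OC[C@@H]2Cc2ccc(OC)c(OC)c2)cc1OC` gives 53200 nM
- compound 2 `COC(=O)[C@H](CCSC)NC(=O)CCC(=O)Oc1ccc(C[C@H]2C(=O)OC[C@@H]2Cc2ccc(OC)c(OC)c2)cc1OC` gives 199000 nM

For the measured compounds named here, both values come from an ADME assay on HeLa cells (Homo sapiens) for cytotoxicity, read by MTT assay (on this read-out higher numbers stand for weaker inhibition and lower numbers for stronger inhibition), where compound 2 holds the higher of the two numbers and compound 1 is its only neighbour. The next compound, compound 3 `COC(=O)[C@@H](NC(=O)CCC(=O)Oc1ccc(C[C@H]2C(=O)OC[C@@H]2Cc2ccc(OC)c(OC)c2)cc1OC)c1c[nH]c2ccccc12`, differs from compound 2 as follows: 1H-indol-3-yl in place of 2-(methylsulfanyl)ethyl on a saturated chain carbon bound to an amide-type nitrogen and a carbonyl carbon. In words, 1H-indol-3-yl stands in place of 2-(methylsulfanyl)ethyl on a saturated chain carbon bound to an amide-type nitrogen and a carbonyl carbon. Going by the values given here, only one measured step bears on this, a 3.7-fold higher number from compound 1 to compound 2 (0.57 log units; beyond the scatter), and it is modest. Among the compounds with values here, no measured compound carries an aromatic group in this place, so the direction is uncertain. Within the data shown here, since compound 2 already sits at 199000 nM, the higher of only two values, a modest move to a lower number in this assay is expected. The expected change is a 2.5-fold lower number from compound 2 to compound 3 (0.40 log units; beyond the scatter). The estimate for compound 3 is 80000 nM, with an expected range from 25000 nM to 220000 nM.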

Compound 3, half-maximal inhibitory concentration: >= 600000 nM
Compound 3 was reported as a limit; the forecaster's own chance of this, stated with the estimate: 10%; at least 7.5-fold (0.87 log units) between middle value and limit.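

In this assay the value of compound 3 is a limit and not a number: the limit of >= 600000 nM in this assay, at which 1 of the 3 values shown sits. Putting 1H-indol-3-yl in place of 2-(methylsulfanyl)ethyl on this saturated chain carbon gives an at least 3.0-fold higher number from compound 2 to compound 3 (0.47 log units; beyond the scatter), and putting it in place of isobutyl gives an at least 11-fold higher number from compound 1 to compound 3 (1.05 log units; beyond the scatter). The position therefore also responds to an aromatic group, not only to a change between saturated chains, and the number moves in the same direction as in a 3.7-fold higher number from compound 1 to compound 2 (0.57 log units; beyond the scatter), with compound 3 the highest of the three.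

On these data alone, how far compound 3 lies past its limit stays open, so the full size of both steps is unknown. The compounds shown also do not separate the two aromatic rings of 1H-indol-3-yl from its hydrogen-bond donor, and they leave open how a phenyl group or a chain ending in a carboxylic acid would read in this assay.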